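Amide substituent changes and paw edema inhibition

The compounds below may be only part of what the source reports. "The series", "measured", "known", "first", "only" and "open" are said of these compounds alone.

Compound 1 `CCNC(=O)CC1CCc2cc(OC)c(OC)cc21`, compound 2 `CCCCNC(=O)CC1CCc2cc(OC)c(OC)cc21` and compound 3 `COc1cc2c(cc1OC)C(CC(=O)NC1CCCC1)CC2` share one core and differ only in the group on the amide-type nitrogen. In a functional assay on the whole organism (strain Wistar) for inhibition, with Rattus norvegicus as the target, read by paw edema, with stated times of 60 min and 4 h, at a dose of 100 mg/kg by the oral route (on this read-out higher numbers stand for more inhibition at the one dose given (going by the name of the read-out) and lower numbers for less inhibition), compound 1 gives 26.6%, compound 2 gives 25% and compound 3 gives 45.3%. Among these three numbers compound 1 stands second highest, with compound 2 nearest (a number 1.6 percentage points lower from compound 1 to compound 2 (within the scatter)) and compound 3 furthest (a number 18.7 percentage points higher from compound 1 to compound 3 (beyond the scatter)); the step of a number 20.3 percentage points higher from compound 2 to compound 3 (beyond the scatter) points the same way, so the cyclopentyl group is the only change so far that moved the read-out beyond the scatter.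

Compound 4 `COc1cc2c(cc1OC)C(CC(=O)N1CCNCC1)CC2` is not yet measured. Its difference from compound 1: piperazin-1-yl in place of ethylamino on a carbonyl carbon. Within the data shown here, no measured step covers a ring that includes the amide-type nitrogen; the steps to compound 3 exchange an open chain for cyclopentyl, and the step from compound 1 to compound 2 changes chain length without effect. The expected step of a number 3.4 percentage points higher from compound 1 to compound 4 (within the scatter) is therefore small, its direction uncertain. For compound 4 the estimate is 30%, with a range from 15% to 48%.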

Compound 4, a percentage reported as inhibition, in the whole organism at one dose (the size of the read-out at that dose, not a potency): 40.6%
Estimate against measurement, compound 4: 10.6 percentage points below; the measured number falls inside the stated range.
By their numbers in this assay, from the lowest: compounds 2 and 1 (each within the scatter of the next); then compounds 4 and 3 (each within the scatter of the next).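

Piperazin-1-yl on the carbonyl carbon moves the number in this assay beyond the scatter from both open chains (a number 14 percentage points higher from compound 1 to compound 4 (beyond the scatter); a number 15.6 percentage points higher from compound 2 to compound 4 (beyond the scatter)), so a change of this size at this position is not confined to cyclopentyl. Compound 4 has no amide hydrogen and compound 3 keeps one, yet the two stay within the scatter (a number 4.7 percentage points lower from compound 3 to compound 4 (within the scatter)), so at this dose the amide hydrogen is not needed for a number at this level. Nothing available explains why the two ring groups stand apart from ethyl and butyl.

Open, from the compounds shown here alone, is whether the second ring nitrogen matters, which piperidin-1-yl or morpholin-4-yl on the same carbonyl carbon would test. Also open, going by these compounds, is how the number responds to ring size, as with cyclohexyl on the amide-type nitrogen.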